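The source may hold more compounds than are shown below. What is called first, only, known or untested is meant among the compounds shown, and "the series" means these compounds.

Among the compounds with values here, in an ADME assay on the whole organism (Rattus norvegicus, strain Sprague-Dawley) for pharmacokinetics, read by LC-MS, with a stated time of 30 min, at a dose of 1 mg/kg by the intravenous route (a higher number here means faster removal of the compound, a lower number slower removal), compound 1 (`N#Cc1ccc(O[C@H]2CN(S(=O)(=O)c3ccc(C(F)(F)F)cc3)C[C@@]2(O)CO)cc1F`) gives 1500 mL/min/kg and stands level with the only other compound measured so far. That other compound is compound 2 (`N#Cc1ccc(O[C@H]2CN(S(=O)(=O)c3ccc(Cl)cc3Cl)C[C@@]2(O)CN)cc1F`), which gives 1100 mL/min/kg in the same test. The two numbers lie within the usual scatter of each other, so neither stands apart, and compound 1 has no clear rank of its own.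

The next compound, compound 3 (`N#Cc1ccc(O[C@H]2CN(S(=O)(=O)c3ccccc3C#N)C[C@@]2(O)CO)cc1F`), keeps the core of compound 1 and changes one group. It carries 2-cyanophenyl in place of 4-(trifluoromethyl)phenyl on a sulfonyl sulfur. Within the data shown here, no measured pair yet shows what a swap at this place does to this assay, so no step beyond the scatter is expected, and any direction can only be a weak guess. The expected change (a 1.5-fold lower number from compound 1 to compound 3 (0.18 log units; within the scatter)) is an estimate that stays inside that scatter. It starts from compound 1 at 1500 mL/min/kg and leans a little towards the lower number. The estimated clearance of compound 3 is 1000 mL/min/kg with an expected range from 450 mL/min/kg to 1800 mL/min/kg for the measurement still to come.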

Compound 3, clearance: 200 mL/min/kg
Beside the measured number, compound 3's estimate is 5.0-fold (0.70 log units) above it; the measured number lies below the stated range.
By their numbers in this assay, from the lowest: compound 3; then compounds 2 and 1 (each within the scatter of the next).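

In this assay the group on the sulfonyl sulfur proves to be a place that matters: 2-cyanophenyl in place of 4-(trifluoromethyl)phenyl gives a 7.5-fold lower number from compound 1 to compound 3 (0.88 log units; beyond the scatter) while the rest of the molecule stays the same. This is the only step shown so far that lies beyond the scatter, and it shows that a single swap at this place can move clearance by a clear margin, which the two earlier compounds could not show. No measurement shown here accounts for why this swap lowers the number.

The swap removes trifluoromethyl and brings in nitrile on a different ring position, so the compounds shown leave open whether the step comes with the nitrile, with the loss of trifluoromethyl, or with where the group stands on the ring. They also leave open how clearance would read with a plain phenyl ring, a phenyl ring bearing a methoxy group, or a pyridine ring on the same sulfonyl sulfur.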